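This account rests on a few compounds, and the source may have more. Where it says the series, first, only, none or still open, it means among the compounds named here.

Of the compounds shown here, three built on one shared core have been tested in an assay on cells with melanin-concentrating hormone receptor 1 (Homo sapiens) as the target, read by radioligand binding; on this read-out lower numbers stand for stronger inhibition and higher numbers for weaker inhibition. Compound 3 `Nc1ccc2cccc(OC3CCCC3)c2n1` carries a cyclopentyl group on an oxygen on an aromatic ring. In this assay compound 3 reaches only a limit, > 2000 nM. Compound 1 `CCOCCOc1cccc2ccc(N)nc12` likewise gives only a limit, > 2000 nM. Compound 2 `Nc1ccc2cccc(OCC3CCCC3)c2n1`, with a cyclopentylmethyl group in that place, gives 53 nM in this assay. Two of the three values thus sit at the limit (the limit of > 2000 nM in this assay, at which 2 of the 3 values shown sit). The step of an at least 37-fold lower number from compound 1 to compound 2 (1.57 log units; beyond the scatter) and the step of an at least 37-fold higher number from compound 2 to compound 3 (1.57 log units; beyond the scatter) are both large, while the step that the two limits leave unreadable from compound 1 to compound 3 cannot be read. Compound 4 `Nc1ccc2cccc(OCCC3CC3)c2n1` differs from compound 3 by 2-cyclopropylethyl in place of cyclopentyl on an oxygen on an aromatic ring. The new group, like the cyclopentylmethyl group of compound 2, is a chain ending in a ring, whereas the group of compound 3 is the ring alone. Because the step of an at least 37-fold higher number from compound 2 to compound 3 (1.57 log units; beyond the scatter) was large, a step of an at least 13-fold lower number from compound 3 to compound 4 (1.12 log units; beyond the scatter) toward a lower number is expected in this assay. Compound 4 is therefore estimated at 150 nM, within 30 nM to 1500 nM.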

Compound 4, half-maximal inhibitory concentration: 492 nM
For compound 4 the middle estimate is 3.3-fold (0.52 log units) below the measured one; the range from low to high includes it.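

In this assay, the same five carbons on the oxygen give a different result when arranged as 2-cyclopropylethyl rather than cyclopentyl, with an at least 4.0-fold lower number from compound 3 to compound 4 (0.60 log units; beyond the scatter), so their count alone does not set the read-out. Cyclopropyl in place of ethoxy at the chain end gives an at least 4.0-fold lower number from compound 1 to compound 4 (0.60 log units; beyond the scatter), which extends the contrast seen with compound 2 to a second chain ending in a ring. A chain ending in a ring still does not guarantee the level of compound 2, as the comparison of these two chains gives a 9.3-fold higher number from compound 2 to compound 4 (0.97 log units; beyond the scatter).

Going by these compounds, the true distance from compound 1 and compound 3 stays open, because both give only a limit: the limit of > 2000 nM in this assay, at which 2 of the 4 values shown sit. Compounds 2 and 4 differ in both ring size and chain length, so a 2-cyclopentylethyl or cyclobutylmethyl group would be needed to separate the two.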